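The source may hold more compounds than are shown below. What is called first, only, known or untested is meant among the compounds shown, and "the series" means these compounds.

Three compounds that share one core have been taken into an ADME assay on Vero cells (Chlorocebus sabaeus) for cytotoxicity, read by MTT assay, with a stated time of 72 h (a lower number here means that less compound is tolerated, a higher number that more compound is tolerated), where the entry for compound 2 `CC1(C)C=Cc2c(ccc(C(=O)/C=C/c3ccc(Br)cc3)c2O)O1` reads "not determined" (no result reported), and a fourth is still to be tested. In this test compound 1 `CC1(C)C=Cc2c(ccc(C(=O)/C=C/c3ccc(Cl)cc3)c2O)O1` gives 92200 nM, and compound 3 `CCOc1cc(/C=C/C(=O)c2ccc3c(c2O)C=CC(C)(C)O3)ccc1F` gives 185000 nM. Compound 2 therefore cannot serve as a measured starting point.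

The compound still to be tested is compound 4 `CC1(C)C=Cc2c(ccc(C(=O)/C=C/c3ccc(C#N)cc3)c2O)O1`. The structural change is cyano in place of bromo on an aromatic carbon, para to a large group. Going by the values given here, nothing measured so far shows what this swap does, and with no value on the compound 2 side, the size of the change cannot be read directly.

In this assay the expectation is therefore for no step beyond the usual scatter, in either direction, from the level of the measured compounds. That expectation rests only on compound 1 at 92200 nM and compound 3 at 185000 nM, so it remains a cautious one, and the range has to stay wide. For compound 4 the estimated value is 100000 nM, with an expected range from 35000 nM to 250000 nM.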

Compound 4, half-maximal cytotoxic concentration: 80200 nM
Estimate against measurement, compound 4: 1.2-fold (0.10 log units) above; the measured number falls inside the stated range.
By their numbers in this assay, from the lowest: compounds 4, 1 and 3 (each within the scatter of the next, the first and the last beyond it).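

Compound 2 carries no number, and the step from it to compound 4 cannot be read. Its close relative compound 1 still gives a first direct view of this position, para to a large group, in this assay: cyano in place of chloro gives a 1.1-fold lower number from compound 1 to compound 4 (0.06 log units; within the scatter). So, in this pair, a chloro group and a cyano group on this aromatic carbon cannot be told apart in how much compound the Vero cells tolerate, even though the cyano group brings a triple bond and a hydrogen-bond acceptor. Nothing measured here offers an explanation for this result.

This is a single pair of compounds, and it does not show whether the same level would hold with an amine, a carboxylic acid or a longer chain at this position. Where the bromo compound itself stands also remains open, as does whether the 4-cyanophenyl group would behave the same way on a compound carrying other changes, since only the one swap on the shared core can be read here.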